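The compounds below may be only part of what the source reports. "The series", "measured", "known", "first", "only" and "open" are said of these compounds alone.

Measured compounds in a functional assay on HeLa cells (Homo sapiens) for cytotoxicity, read by MTT assay, with a stated time of 2 days, tested at 10 uM; a higher number here means a weaker effect of the compound at the concentration tested, a lower number a stronger effect:

compound 1 `CC(=O)c1cc(-c2ccccc2)cc2cc(-c3ccc(F)cc3)[nH]c12`, 76.9%
compound 2 `COc1ccc(-c2cc3cc(-c4ccccc4)cc(C(C)=O)c3[nH]2)cc1`, 51.6%
compound 3 `CC(=O)c1cc(/C=C/c2ccc(F)cc2)cc2cc(-c3ccc(F)cc3)[nH]c12`, 41.9%

Compound 4 `COc1ccc(-c2cc3cc(/C=C/c4ccc(F)cc4)cc(C(C)=O)c3[nH]2)cc1` has not yet been measured in this assay. It stands to compound 3 as compound 2 stands to compound 1: the change methoxy in place of fluoro on an aromatic carbon is the same as methoxy in place of fluoro on an aromatic carbon, both on an aromatic carbon para to a large group, and it occurs two times among the compounds shown. In the measured pair that change gave a number 25.3 percentage points lower from compound 1 to compound 2 (beyond the scatter). The cores of the two pairs differ by 2-(4-fluorophenyl)ethenyl in place of phenyl on an aromatic carbon, which on its own gave a number 35 percentage points lower from compound 1 to compound 3 (beyond the scatter). Compound 3 and compound 2 are within the scatter of each other. Since the change is the same, a step of the same direction is expected from compound 3 to compound 4, a number 16.9 percentage points lower from compound 3 to compound 4 (beyond the scatter), though its size rests on one measured pair only and may shrink as the numbers move toward the low end of the read-out. Compound 4 is therefore estimated at 25%, between 8% and 45%.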

Compound 4, a percentage reported as activity, at one concentration (the size of the read-out at that concentration, not a potency): 25.8%
Beside the measured number, compound 4's estimate is 0.8 percentage points below it, and the stated range covers the measured number.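

In this assay, methoxy in place of fluoro carries over to the core bearing 2-(4-fluorophenyl)ethenyl, giving a number 16.1 percentage points lower from compound 3 to compound 4 (beyond the scatter), and the step matches the earlier one: the same change on two cores in this assay, a number 25.3 percentage points lower (beyond the scatter) from compound 1 to compound 2 and a number 16.1 percentage points lower (beyond the scatter) from compound 3 to compound 4, 9.2 percentage points apart, within the scatter of two such steps. Read the other way, 2-(4-fluorophenyl)ethenyl in place of phenyl gives a number 25.8 percentage points lower from compound 2 to compound 4 (beyond the scatter), and this step also matches its earlier counterpart: the same change on two cores in this assay, a number 35 percentage points lower (beyond the scatter) from compound 1 to compound 3 and a number 25.8 percentage points lower (beyond the scatter) from compound 2 to compound 4, 9.2 percentage points apart, within the scatter of two such steps. Both comparisons rest on the same four compounds, so they show the two changes combining consistently here, not that either change would transfer to other cores in the series.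

As far as these compounds go, whether an amine or a carboxylic acid, on the aromatic carbon para to a large group, would move the read-out as methoxy does remains open. So does the effect of a longer chain in place of 2-(4-fluorophenyl)ethenyl.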